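This account rests on a few compounds, and the source may have more. Where it says the series, first, only, none or still open, it means among the compounds named here.

Of the compounds shown here, three that share one core have been measured in a physicochemical assay (Homo sapiens) for solubility, with a stated time of 18 h, at pH 7.4; a higher number here means a more soluble compound, a lower number a less soluble compound. Compound 1 `CCN(CC)c1ccc(/C=C2/SC(Nc3ccccc3)=NC2=O)cc1` gives 0.1 ug/mL. Compound 2 `CN1CCN(c2ccc(/C=C3/SC(Nc4ccccc4)=NC3=O)cc2)CC1` gives 0.35 ug/mL, and compound 3 `CN1CCN(c2ccc(/C=C3/SC(Nc4ccccc4Cl)=NC3=O)cc2)CC1` gives 0.43 ug/mL. Compound 2 thus stands second highest of the three numbers, nearest to compound 3 and furthest from compound 1. The two steps among them were a 3.5-fold higher number from compound 1 to compound 2 (0.54 log units; beyond the scatter) and a 1.2-fold higher number from compound 2 to compound 3 (0.09 log units; within the scatter).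

Compound 4 `CN1CCN(c2ccc(/C=C3/SC(Nc4ccc(Oc5ccccc5)cc4)=NC3=O)cc2)CC1` has not yet been measured in this assay. It differs from compound 2 in one place: phenoxy in place of hydrogen on an aromatic carbon. Going by the values given here, of the measured steps, only the one between compound 2 and compound 3 alters the same ring, and that step, a 1.2-fold higher number from compound 2 to compound 3 (0.09 log units; within the scatter), lay within the scatter. Among the compounds with values here, no measured step adds a group as large as phenoxy, so the guidance is weak. The expectation is a small decrease or none beyond the scatter, a step of a 1.8-fold lower number from compound 2 to compound 4 (0.24 log units; within the scatter). Compound 4 is therefore estimated at 0.2 ug/mL, with a range from 0.05 ug/mL to 0.6 ug/mL.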

Compound 4, solubility: 0.1 ug/mL
Beside the measured number, compound 4's estimate is 2.0-fold (0.30 log units) above it; measured number inside the range.
By their numbers in this assay, from the lowest: compounds 1 and 4 (each within the scatter of the next); then compounds 2 and 3 (each within the scatter of the next).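

In this assay, the ring bearing the change now shows a step beyond the scatter: with phenoxy in place of hydrogen, para to a large group, the number falls (a 3.5-fold lower number from compound 2 to compound 4 (0.54 log units; beyond the scatter)). Going by these compounds alone, the only earlier change on this ring, chloro in place of hydrogen, gave a step within the scatter (a 1.2-fold higher number from compound 2 to compound 3 (0.09 log units; within the scatter)), so this ring does not tolerate every replacement of hydrogen without a measurable step. No measurement shown accounts for the difference between these two steps.

Going by these compounds, it remains open whether the step in compound 4 follows from the added ring or from its linking oxygen, a question that a phenyl or methoxy group at the same place would help to separate. On these data alone, it is also open how the number would respond to a carboxylic acid or an amine on the outer ring of the phenoxy group.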